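The source may report more compounds than this note shows. Statements on the series, on what has been measured and on what is new or still open speak of the compounds shown alone.

Compound 1 `Cc1cc(Nc2cc(-c3ccccc3)[nH]n2)n2nc(SCc3c(Cl)cccc3Cl)nc2n1` has the highest number of the three compounds measured in a functional assay on MGC-803 cells (Homo sapiens) for inhibition, read by MTT assay, with a stated time of 72 h (a lower number here means a stronger inhibitor, a higher number a weaker inhibitor), where compound 1 gives 5280 nM. Compound 3 `Cc1cc(Nc2cc(-c3cccs3)[nH]n2)n2nc(SCc3ccc(Br)cc3)nc2n1` gives 3770 nM, a gap that lies within the scatter, whereas compound 2 `Cc1cc(Nc2ccn(Cc3nc(C)c4ccccc4n3)n2)n2nc(SCc3ccc(Br)cc3)nc2n1` gives 960 nM, a gap beyond it. Compound 4 `C=CCSc1nc2nc(C)cc(Nc3cc(-c4ccccc4)[nH]n3)n2n1` is not yet measured; it differs from compound 1 by vinyl in place of 2,6-dichlorophenyl on a saturated chain carbon bound to a sulfur. Among the compounds with values here, no two measured compounds differ in a single place, so there is no measured step to show what a change of this kind does here. A modest step toward a higher number is expected, a 1.5-fold higher number from compound 1 to compound 4 (0.18 log units; within the scatter). Compound 4 is expected to give 8000 nM in this assay, with a range from 2500 nM to 25000 nM.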

Compound 4, half-maximal inhibitory concentration: 17200 nM
Estimate against measurement, compound 4: 2.2-fold (0.33 log units) below; measured number inside the range.
By their numbers in this assay, from the lowest: compound 2; then compounds 3 and 1 (each within the scatter of the next); then compound 4.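

Allylsulfanyl in place of (2,6-dichlorobenzyl)sulfanyl in this assay gives a 3.3-fold higher number from compound 1 to compound 4 (0.51 log units; beyond the scatter) as the first single-place step in the series. This shows that the group on the sulfur affects the number on the core of compound 1, with 2,6-dichlorobenzyl giving the lower number of the two groups.

A single step cannot separate the contribution of the aromatic ring from that of the two chlorines; an unsubstituted benzyl or a saturated propyl chain would address this. The data shown offer no measured basis for explaining the step.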